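Shortening the ester chain: from pentyl to ethyl

The source may hold more compounds than are shown below. What is called first, only, known or untested is meant among the compounds shown, and "the series" means these compounds.

Measured compounds in an assay on isolated protein for inhibition of serine protease 1 (Homo sapiens); on this read-out lower numbers stand for stronger inhibition and higher numbers for weaker inhibition:
- compound 1 `CCCCOC(=O)c1ccc(CN)cc1` gives 910000000 nM
- compound 2 `NCc1ccc(C(=O)OCc2ccc(Cl)cc2)cc1` gives 30000000 nM
- compound 3 `CCCCCOC(=O)c1ccc(CN)cc1` gives 700000000 nM

All three share the same aminomethyl-substituted benzoate core and differ only in the alcohol part of the ester. Compound 3 stands second highest of the three numbers: its nearest neighbour is compound 1, whose number is higher by a 1.3-fold lower number from compound 1 to compound 3 (0.11 log units; within the scatter), a gap within the scatter, while compound 2 sits far lower, beyond the scatter.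

The next compound, compound 4 `CCOC(=O)c1ccc(CN)cc1`, has not yet been measured. It arises from compound 3 by the change (hydrogen in place of propyl on a saturated chain carbon, two bonds along the chain from an oxygen next to a carbonyl group).

Going by the values given here, the only measured step that bears on this change is the one from compound 1 to compound 3, which lengthens the same chain by one carbon and moves the number by a 1.3-fold lower number from compound 1 to compound 3 (0.11 log units; within the scatter), within the scatter. Among the compounds with values here, that suggests the chain length matters little over one carbon, but no measured pair covers a loss of three carbons at once, so the expectation for compound 4 is uncertain and leans towards no change beyond the scatter, or at most a modest rise. For compound 4 the expected value is 1200000000 nM, with a range from 400000000 nM to 4000000000 nM, corresponding to an estimated step of a 1.7-fold higher number from compound 3 to compound 4 (0.23 log units; within the scatter) in this assay.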

Compound 4, inhibition constant: 357000000 nM
Compound 4: middle estimate off by 3.4-fold (0.53 log units), on the high side; the measured number lies below the stated range.
By their numbers in this assay, from the lowest: compound 2; then compounds 4, 3 and 1 (each within the scatter of the next, the first and the last beyond it).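

In this assay the cut from pentyl to ethyl, which puts hydrogen in place of propyl on this chain carbon, gives a 2.0-fold lower number from compound 3 to compound 4 (0.29 log units; within the scatter) and so does not separate the two compounds. Measured against the butyl ester, the same kind of change, now hydrogen in place of ethyl, gives a 2.5-fold lower number from compound 1 to compound 4 (0.41 log units; beyond the scatter) as a modest step, the first among these simple chain esters to clear the scatter. Shortening the chain at this position therefore does not weaken inhibition here, and nothing available explains the small shift.

Still open, as far as these compounds go, is whether a methyl ester, or a branched chain such as isopropyl, would behave like the ethyl ester. Also open, from the compounds shown here alone, is whether an amide or a carboxylic acid in place of the ester would keep any inhibition at all.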